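Piperidinyl for Pyrrolidinyl on a Thiocarbonyl Carbon

The compounds below may be only part of what the source reports. "The series", "measured", "known", "first", "only" and "open" are said of these compounds alone.

Compound 1 `O=c1c(SC(=S)N2CCCC2)coc2ccc(Cl)cc12` and compound 2 `O=c1c(SC(=S)N2CCCCC2)coc2ccc(Cl)cc12` share one core and differ only in piperidin-1-yl in place of pyrrolidin-1-yl on a thiocarbonyl carbon. In a functional assay on HEp-2 cells (Homo sapiens) for antiproliferative activity, read by MTT assay, with a stated time of 72 h (on this read-out lower numbers stand for stronger inhibition and higher numbers for weaker inhibition), compound 1 gives 26000 nM, and compound 2 gives 12200 nM; the step between them is a 2.1-fold lower number from compound 1 to compound 2 (0.33 log units; beyond the scatter). Compound 3 `CCOC(=O)c1cc(=O)c2cc(CSC(=S)N3CCCC3)ccc2o1` is built on a different core, and the difference between the two cores is not broken down here. In this assay compound 3 gives 8900 nM, a number within the scatter of that of compound 2 and beyond the scatter against that of compound 1. Compound 4 `CCOC(=O)c1cc(=O)c2cc(CSC(=S)N3CCCCC3)ccc2o1` has not yet been measured; it differs from compound 3 by piperidin-1-yl in place of pyrrolidin-1-yl on a thiocarbonyl carbon, the same change in the same place as the one between the first two compounds. For the measured compounds named here, because the earlier step was a 2.1-fold lower number from compound 1 to compound 2 (0.33 log units; beyond the scatter), a step of about the same size is expected here, namely a 2.0-fold lower number from compound 3 to compound 4 (0.30 log units; within the scatter), though the core is different and only a single earlier example of this change exists. Compound 4 is therefore estimated at 4500 nM in this assay, with a likely range from 2200 nM to 11000 nM.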

Compound 4, half-maximal inhibitory concentration: 3400 nM
The estimate for compound 4 lay 1.3-fold (0.12 log units) above the measured number; measured number inside the range.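

In this assay, the exchange of pyrrolidin-1-yl for piperidin-1-yl on a thiocarbonyl carbon gives a 2.6-fold lower number from compound 3 to compound 4 (0.42 log units; beyond the scatter), so on the core of compound 3 the step runs the same way as on the core of compound 1. Set side by side, the two steps do not differ: the same change on two cores in this assay, a 2.1-fold lower number (0.33 log units; beyond the scatter) from compound 1 to compound 2 and a 2.6-fold lower number (0.42 log units; beyond the scatter) from compound 3 to compound 4, 1.2-fold (0.09 log units) apart, within the scatter of two such steps. In these two pairs, then, the change carried from one core to the other in both direction and size, but two pairs do not show that it would carry to any further core, and they do not explain why the piperidin-1-yl compounds give the lower numbers.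

The compounds shown leave open whether the step extends to other amines on the thiocarbonyl carbon, such as morpholin-4-yl or an open-chain diethylamino group. They also leave open whether it survives when the ethyl ester of compound 3 and compound 4 is replaced by a carboxylic acid.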